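The source may report more compounds than this note shows. Statements on the series, on what has been measured and on what is new or still open speak of the compounds shown alone.

Compound 1 `O=C(CN1CCN(c2ccccc2F)CC1)Nc1ccc(C(=O)/C=C/c2cn(Cc3ccc(Br)cc3)nn2)cc1` is the reference point here. Going by the values given here, in a functional assay on A549 cells (Homo sapiens) for inhibition, read by MTT assay (a higher number here means a weaker inhibitor, a lower number a stronger inhibitor), compound 1 gives 14700 nM, the lowest of the two numbers so far. Among the compounds with values here, its nearest neighbour is compound 2 `O=C(CN1CCN(c2ccc([N+](=O)[O-])cc2)CC1)Nc1ccc(C(=O)/C=C/c2cn(Cc3ccc(Br)cc3)nn2)cc1`; in this assay compound 2 gives 45500 nM, and the single measured step, a 3.1-fold higher number from compound 1 to compound 2 (0.49 log units; beyond the scatter), concerns the aryl group on the amine nitrogen in the ring.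

Compound 3 `CCCCCCCCCCn1cc(/C=C/C(=O)c2ccc(NC(=O)CN3CCN(c4ccccc4F)CC3)cc2)nn1` differs from compound 1 at another site: nonyl in place of 4-bromophenyl on a saturated chain carbon bound to an aromatic nitrogen. Within the data shown here, no measured step touches that position, so the step from compound 1 to compound 2 bears on it only indirectly, as a sign that one change at the periphery of the shared core can shift the number by a modest amount. Lacking a direct precedent, the expected step of a 1.0-fold higher number from compound 1 to compound 3 (0.01 log units; within the scatter) is set as none beyond the scatter, with the range widened on both sides. Compound 3 is therefore estimated to give about 15000 nM in this assay, between 4500 nM and 50000 nM.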

Compound 3, half-maximal inhibitory concentration: 57000 nM
Beside the measured number, compound 3's estimate is 3.8-fold (0.58 log units) below it; the whole stated range lies below it.
By their numbers in this assay, from the lowest: compound 1; then compounds 2 and 3 (each within the scatter of the next).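

In this assay, going by these compounds alone, the position on a saturated chain carbon bound to an aromatic nitrogen proves sensitive to the group it carries: nonyl in place of 4-bromophenyl gives a 3.9-fold higher number from compound 1 to compound 3 (0.59 log units; beyond the scatter) and so a weaker inhibitor, the first measured change at this site. The step removes the aromatic ring and the bromine and brings in an open carbon chain all at once, so this one comparison cannot separate the contribution of the ring, the halogen or the chain. Nothing measured here accounts for the step.

On these data alone, whether 4-chlorophenyl or unsubstituted phenyl would keep the number of compound 1, and how a shorter chain such as butyl would compare with nonyl, remains open. Also open, as far as these compounds go, is whether the step would be the same with the 4-nitrophenyl group of compound 2 on the amine nitrogen in the ring.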